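Hydroxy in place of cyano: expected plasma level

The source may hold more compounds than are shown below. What is called first, only, known or untested is meant among the compounds shown, and "the series" means these compounds.

- compound 1 `Cc1cc(C)c(N(C)C)c(C)c1NC(=O)c1sccc1S(=O)(=O)Nc1onc(C)c1Cl` gives 6620 nM in an in vivo ADME assay on the whole organism (plasma) for pharmacokinetics, with Rattus norvegicus as the target, at a dose of 50 mg/kg by the oral route; a lower number here means less compound in the circulation, a higher number more compound in the circulation at the dose given
- compound 2 `Cc1cc(C)c(NC(=O)c2sccc2S(=O)(=O)Nc2onc(C)c2Cl)c(C)c1C#N` gives 37200 nM in this assay

Compound 2 is the higher of the two measured compounds, and compound 3 `Cc1cc(C)c(NC(=O)c2sccc2S(=O)(=O)Nc2onc(C)c2Cl)c(C)c1O` remains unmeasured. The change from compound 2 is hydroxy in place of cyano on an aromatic carbon, para to a methyl group: hydroxy in place of cyano on an aromatic carbon. Among the compounds with values here, the one measured step touches the same place, a 5.6-fold higher number from compound 1 to compound 2 (0.75 log units; beyond the scatter), and no hydroxy compound has been measured. A modest fall is therefore expected, though this direction is uncertain. The expected change is a 3.7-fold lower number from compound 2 to compound 3 (0.57 log units; beyond the scatter) on this estimate. For compound 3 the estimated value is 10000 nM, within an expected range of 2500 nM to 35000 nM overall.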

Compound 3, maximal plasma concentration: 106000 nM
For compound 3 the middle estimate is 11-fold (1.03 log units) below the measured one, and the stated range ends below it.
By their numbers in this assay, from the lowest: compound 1; then compound 2; then compound 3.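

Replacing cyano with hydroxy at this position, para to a methyl group, gives a 2.8-fold higher number from compound 2 to compound 3 (0.45 log units; beyond the scatter) in this assay and, against dimethylamino, a 16-fold higher number from compound 1 to compound 3 (1.20 log units; beyond the scatter) on the same scale. All three groups at this aromatic carbon now separate beyond the scatter, with dimethylamino lowest, cyano in the middle and hydroxy highest. Nothing measured here bears on why the order runs this way.

Going by these compounds, whether methoxy, a primary amine or a carboxylic acid at this carbon would match or pass hydroxy stays open. Changes elsewhere on the shared core, with hydroxy kept in place, also remain open.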